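A few compounds are considered here, and "the series" means these few. Any claim that something is new, unique, unknown or untested is made for them only; others in the source may bear on it.

Of the compounds shown here, three that share one core have been measured in an assay on Sf9 cells for inhibition of protein deacetylase HDAC6 (Homo sapiens), read by fluorescence, with a stated time of 40 min, tested at 100 nM; on this read-out higher numbers stand for more inhibition at the one concentration tested (going by the name of the read-out) and lower numbers for less inhibition. Compound 1 `COc1ccc(-n2nc(-c3ccccc3)nc2CNc2ccc(C(=O)NO)cc2)cc1` gives 63.4%. Compound 2 `O=C(NO)c1ccc(NCc2nc(-c3ccccc3)nn2-c2ccc(Br)cc2)cc1` gives 65.9% in this assay. Compound 3 `O=C(NO)c1ccc(NCc2nc(-c3ccccc3)nn2-c2cccc(Cl)c2)cc1` gives 62.3%. Compound 3 carries the smallest of the three numbers, though its separation from the other two is small: a number 1.1 percentage points lower from compound 1 to compound 3 (within the scatter), and a number 3.6 percentage points lower from compound 2 to compound 3 (within the scatter). The remaining step was also within the scatter: a number 2.5 percentage points higher from compound 1 to compound 2 (within the scatter).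

Compound 4 `O=C(NO)c1ccc(NCc2nc(-c3ccccc3)nn2-c2ccc(F)cc2)cc1` has not yet been measured. It differs from compound 3 in one place: 4-fluorophenyl in place of 3-chlorophenyl on an aromatic nitrogen. Going by the values given here, the steps that bear on this change are those that likewise swap the group on the same aromatic nitrogen, from compound 1 to compound 3 and from compound 2 to compound 3; both stayed within the scatter, and so did the step from compound 1 to compound 2. Three different groups on that nitrogen have therefore given much the same inhibition, and no step beyond the scatter is expected here either, with a number 1.7 percentage points higher from compound 3 to compound 4 (within the scatter) being the expected step. Compound 4 is estimated to give 64% in this assay, with an expected range from 54% to 74%.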

Compound 4, a percentage reported as inhibition, at one concentration (the size of the read-out at that concentration, not a potency): 67.6%
Compound 4: the middle estimate sits 3.6 percentage points below what was measured; low and high end bracket the measured number.
By their numbers in this assay, from the lowest: compounds 3, 1, 2 and 4 (each within the scatter of the next).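

In this assay, the swap of 3-chlorophenyl for 4-fluorophenyl on the aromatic nitrogen gives a number 5.3 percentage points higher from compound 3 to compound 4 (within the scatter), the largest step yet seen at this position, but it stays inside the scatter, so a fourth group here still cannot be told apart from the others. On the aromatic carbon of that same phenyl ring, fluoro in place of bromo gives a number 1.7 percentage points higher from compound 2 to compound 4 (within the scatter), and fluoro in place of methoxy gives a number 4.2 percentage points higher from compound 1 to compound 4 (within the scatter), so three different substituents at that carbon also give much the same inhibition. The change to compound 4 replaces the halogen and shifts its place on the ring in one move, so these two changes cannot be pulled apart, and nothing measured speaks to what lies behind these numbers. 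

As far as these compounds go, it remains open whether a group of another kind on that phenyl ring, such as an amine or a carboxylic acid, or a butyl chain in place of the whole ring, would give a step beyond the scatter. From the compounds shown here alone, all four numbers come from a single concentration, so potency itself is still unknown, as is the role of the phenyl group that all four compounds share.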